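Swapping methyl for fluoro on the hydrazone aryl ring

The source may report more compounds than this note shows. Statements on the series, on what has been measured and on what is new or still open speak of the compounds shown alone.

Measured so far:
compound 1, `O=C(COc1cccc2ccccc12)N/N=C/c1c(O)ccc2ccccc12`: 2.12 ug/mL
compound 2, `COc1ccc(/C=N/NC(=O)COc2cccc3ccccc23)cc1OC`: 14.7 ug/mL
compound 3, `Cc1ccc(/C=N/NC(=O)COc2cccc3ccccc23)cc1`: 83.9 ug/mL

All three compounds share a core and differ in the aromatic group hung on the hydrazone. In an ADME assay on MT4 cells (Homo sapiens) for cytotoxicity, read by MTT assay, with a stated time of 4 days (a lower number here means that less compound is tolerated, a higher number that more compound is tolerated), compound 3 gives the highest number of the three, well beyond the scatter from compound 2 and further still from compound 1, so it is the best tolerated of the measured set.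

Compound 4, `O=C(COc1cccc2ccccc12)N/N=C/c1ccc(F)cc1`, is not yet measured. It differs from compound 3 by fluoro in place of methyl on an aromatic carbon. Within the data shown here, both groups are single heavy atoms on the same aromatic carbon, and no comparable step exists among the measured compounds, so the step of a 1.4-fold lower number from compound 3 to compound 4 (0.15 log units; within the scatter) is expected to be small, likely none beyond the scatter, perhaps a slight fall. Compound 4 is therefore estimated at 60 ug/mL, within 20 ug/mL to 150 ug/mL.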

Compound 4, half-maximal cytotoxic concentration: 65.1 ug/mL
The estimate for compound 4 lay 1.1-fold (0.04 log units) below the measured number, within the range that was stated.
By their numbers in this assay, from the lowest: compound 1; then compound 2; then compounds 4 and 3 (each within the scatter of the next).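

Fluoro in place of methyl on this aromatic carbon, para to a large group, gives the first one-place comparison in the set: in this assay it is a 1.3-fold lower number from compound 3 to compound 4 (0.11 log units; within the scatter). At this position, then, these two groups cannot be told apart in how much compound the cells tolerate. Nothing measured here speaks to why that is so.
Still open, from the compounds shown here alone, is whether an amine or a carboxylic acid on the same carbon would shift the number beyond the scatter. Also open, going by these compounds, is whether the swap of methyl for fluoro would stay just as silent on a different core.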